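Working notes: from compound 2 to compound 3

This account rests on a few compounds, and the source may have more. Where it says the series, first, only, none or still open, it means among the compounds named here.

- compound 1 `COc1cc(/C=C/C(=O)/C=C/c2cccc3ccccc23)ccc1OCc1cn(CCCOc2cc(=O)oc3ccccc23)nn1` gives 66%
- compound 2 `COc1cc(/C=C/C(=O)/C=C/c2ccco2)ccc1OCc1cn(CCCOc2cc(=O)oc3ccccc23)nn1` gives 51%

Both values come from a functional assay on HCT-116 cells (Homo sapiens) for inhibition, read by sulforhodamine B assay, with a stated time of 48 h, tested at 50 uM (on this read-out lower numbers stand for less inhibition of growth and higher numbers for more inhibition of growth at the one concentration tested), and compound 2 stands as the lower of the two, beyond the scatter. Compound 3 `COc1cccc(/C=C/C(=O)/C=C/c2ccc(OCc3cn(CCCOc4cc(=O)oc5ccccc45)nn3)c(OC)c2)c1` has not yet been measured. The change is 3-methoxyphenyl in place of furan-2-yl on a double-bonded chain carbon bound to a double-bonded chain carbon and it places 3-methoxyphenyl where furan-2-yl stood on a double-bonded chain carbon bound to a double-bonded chain carbon. For the measured compounds named here, the one measured step at this place is a number 15 percentage points lower from compound 1 to compound 2 (beyond the scatter) with furan-2-yl in place of naphthalen-1-yl. A single step gives no trend. Going by the values given here, compound 3 again carries a ring of carbon only there, so a modest rise is expected, no larger than that step. The expected change is a number 9 percentage points higher from compound 2 to compound 3 (within the scatter) and it rests on that step alone. The estimate for compound 3 is 60% with 46% to 74% as the expected range.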

Compound 3, percent growth inhibition at one concentration: 55%
For compound 3 the middle estimate is 5 percentage points above the measured one; low and high end bracket the measured number.
By their numbers in this assay, from the lowest: compounds 2 and 3 (each within the scatter of the next); then compound 1.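

In this assay, 3-methoxyphenyl in place of furan-2-yl on a double-bonded chain carbon bound to a double-bonded chain carbon gives a number 4 percentage points higher from compound 2 to compound 3 (within the scatter) so a six-membered aromatic ring of carbon only does not separate from the five-membered ring at this place. Naphthalen-1-yl now stands apart from two different groups, with a number 11 percentage points lower from compound 1 to compound 3 (beyond the scatter) adding to the earlier a number 15 percentage points lower from compound 1 to compound 2 (beyond the scatter) and leaving compound 1 as the highest of the three. Nothing available bears on the reason for these differences.

Open, from the compounds shown here alone, is whether a dimethylamino group or a carboxylic acid on the phenyl ring, or a longer chain at this place, would shift the number. Compound 1 alone carries naphthalen-1-yl, so one example cannot show whether its higher number extends to other groups of that size.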